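Reshuffling a side group with no starting number

The source may hold more compounds than are shown below. What is called first, only, known or untested is meant among the compounds shown, and "the series" means these compounds.

Among the compounds with values here, in a physicochemical assay for lipophilicity (on this read-out higher numbers stand for higher lipophilicity and lower numbers for lower lipophilicity), compound 1 (`CNC(=O)c1cc(C(=O)N[C@H]2CC[C@H](O)CC2)n([C@@H](C)c2ccccc2Cl)n1`) gives 3.9 as its reading, and this is the only number available. Compound 2 (`CC[C@@H](c1ccccc1)n1nc(C(=O)NC)cc1C(=O)N[C@H]1CC[C@H](O)CC1`) shares the core of compound 1, yet the result of compound 2 is "not determined" (no result reported) and so it has no place on this scale. That leaves a comparison without a starting point.

Compound 3 (`CNC(=O)c1cc(C(=O)N[C@H]2CC[C@H](O)CC2)n([C@@H](C)c2cccc(C)c2)n1`) is built from the same atoms as compound 2, joined differently. It carries 1-(3-methylphenyl)ethyl in place of 1-phenylpropyl on an aromatic nitrogen. The group that leaves and the group that enters match in the counts shown, but no measured pair here shows what such a swap does. Without a value for compound 2, the size of this step cannot be read from the data. No step beyond the usual scatter is expected in this assay, in either direction. The expectation therefore leans on compound 1 and its 3.9 reading, a single and imperfect guide. Compound 3 is expected to read about 3.8 in this assay, with an estimated range from 3.3 to 4.3 once measured.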

Compound 3, distribution coefficient: 3.4
Beside the measured number, compound 3's estimate is 0.40 log units above it; the measured number falls inside the stated range.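

Compound 3 gives this series its first measured step: in this assay, 3-methylphenyl in place of 2-chlorophenyl, on a saturated chain carbon bound to an aromatic nitrogen and a saturated chain carbon, gives a number 0.50 log units lower from compound 1 to compound 3 (beyond the scatter) for this change. A lone reading could not show that the aromatic group at this place can shift the result by more than repeat measurements would. This single pair, however, replaces the chlorine with a methyl group and also changes where that group is attached to the ring, so the contribution of each change cannot be separated.

Within the data shown here, compound 2 has no reading, so no step involving it can be read, and the swap of 1-phenylpropyl for 1-(3-methylphenyl)ethyl remains unresolved, as do the readings that an unsubstituted phenyl, a 3-chlorophenyl or a 2-methylphenyl group would give on the same carbon. No separate measurement is available to explain the step seen here.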